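A few compounds are considered here, and "the series" means these few. Any claim that something is new, unique, unknown or untested is made for them only; others in the source may bear on it.

Measured in a functional assay on DU-145 cells (Homo sapiens) for inhibition, read by trypan blue exclusion, with a stated time of 96 h; a lower number here means a stronger inhibitor of growth, a higher number a weaker inhibitor of growth:
- Compound 1 `Cc1cc(C)cc(/C=C(\C(=O)c2ccc(Cl)cc2)S(=O)(=O)Cc2ccc(Cl)cc2)c1`: 1000 nM.
- Compound 2 `Cc1ccc(S(=O)(=O)/C(=C/c2cccs2)C(=O)c2ccc(Cl)cc2)cc1`: 25000 nM.
- Compound 3 `Cc1ccc(S(=O)(=O)/C(=C/c2c(O)cc(O)cc2O)C(=O)c2ccc(Cl)cc2)cc1`: > 100000 nM, a limit of the assay and not a number.

Compound 3 gives no number and stands at the limit of > 100000 nM in this assay, at which 1 of the 3 values shown sits.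

The next compound is compound 4 `Cc1ccc(S(=O)(=O)/C(=C/c2cc(C)cc(C)c2)C(=O)c2ccc(Cl)cc2)cc1`, with the change (3,5-dimethylphenyl in place of 2,4,6-trihydroxyphenyl on a double-bonded chain carbon bound to a double-bonded chain carbon).

Within the data shown here, one measured step bears directly on this place: an at least 4.0-fold higher number from compound 2 to compound 3 (0.60 log units; beyond the scatter). That step brought in the 2,4,6-trihydroxyphenyl group that now leaves, so a move in the opposite direction, to a lower number in this assay, is expected. Compound 1 also carries 3,5-dimethylphenyl at this place and gives 1000 nM, but it differs from compound 4 elsewhere, so it serves only as a rough guide. Compound 2, at 25000 nM, gives a second reference point.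

The expected change is beyond the scatter, with an estimated at least 20-fold lower number from compound 3 to compound 4 (1.30 log units; beyond the scatter).

For compound 4 the estimated value is 5000 nM, with an expected range of 800 nM to 30000 nM.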

Compound 4, concentration for 50% growth inhibition: 1000 nM
Beside the measured number, compound 4's estimate is 5.0-fold (0.70 log units) above it; the measured number falls inside the stated range.
By their numbers in this assay, from the lowest: compounds 1 and 4 (each within the scatter of the next); then compound 2. At a limit, above all of these: compound 3.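

In this assay, with 3,5-dimethylphenyl entering on a double-bonded chain carbon bound to a double-bonded chain carbon, the steps read a 25-fold lower number from compound 2 to compound 4 (1.40 log units; beyond the scatter) and an at least 100-fold lower number from compound 3 to compound 4 (2.00 log units; beyond the scatter), the second only a bound. Compound 3 remains a limit of the assay and not a number: the limit of > 100000 nM in this assay, at which 1 of the 4 values shown sits. On the sulfonyl sulfur, 4-methylphenyl in place of 4-chlorobenzyl gives no change at the digits printed from compound 1 to compound 4 (within the scatter), so with 3,5-dimethylphenyl present this exchange leaves the growth inhibition reading within the scatter.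

From the compounds shown here alone, how an amine or a carboxylic acid on the aromatic ring at the double-bonded chain carbon would read remains open. Also open, going by these compounds, is whether the exchange on the sulfonyl sulfur would stay within the scatter with thiophen-2-yl or 2,4,6-trihydroxyphenyl in place of 3,5-dimethylphenyl.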